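A few compounds are considered here, and "the series" means these few. Any claim that something is new, unique, unknown or untested is made for them only; others in the source may bear on it.

Measured compounds:
- compound 1, `CCCCCCCCCCCC[C@@H](O)[C@H]1CC[C@H]([C@H](O)CCCCCCCCCCNC(=O)c2cccs2)O1`: 42.7 nM in a functional assay on OVCAR-3 cells (Homo sapiens) for inhibition, read by colorimetric assay and sulforhodamine B assay, with a stated time of 48 h; on this read-out higher numbers stand for weaker inhibition of growth and lower numbers for stronger inhibition of growth
- compound 2, `CCCCCCCCCCCC[C@@H](O)[C@H]1CC[C@H]([C@H](O)CCCCCCCCCCNC(=O)c2ccoc2)O1`: 100000 nM
- compound 3, `CCCCCCCCCCCC[C@@H](O)[C@H]1CC[C@H]([C@H](O)CCCCCCCCCCNC(=O)c2ccsc2)O1`: 1700 nM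

Among these three, compound 2 gives the highest number in this assay: the step of a 2300-fold higher number from compound 1 to compound 2 (3.37 log units; beyond the scatter) and the step of a 59-fold lower number from compound 2 to compound 3 (1.77 log units; beyond the scatter) both leave it far from its neighbours, so on these numbers compound 2 is the weakest inhibitor of growth of the set.

Compound 4, `CCCCCCCCCCCC[C@@H](O)[C@H]1CC[C@H]([C@H](O)CCCCCCCCCCNC(=O)c2ccnn2C)O1`, has not yet been measured. It differs from compound 2 in one place: 1-methyl-1H-pyrazol-5-yl in place of furan-3-yl on a carbonyl carbon. The two measured steps that bear on this change are those in which the furan-3-yl group on the carbonyl carbon is swapped for another five-membered aromatic ring, a 2300-fold higher number from compound 1 to compound 2 (3.37 log units; beyond the scatter) and a 59-fold lower number from compound 2 to compound 3 (1.77 log units; beyond the scatter). In both, the furan-3-yl compound gave by far the higher number, and the step of a 40-fold higher number from compound 1 to compound 3 (1.60 log units; beyond the scatter) shows that the size of the effect depends strongly on which ring enters. For compound 4 a lower number than for compound 2 is therefore expected, with wide uncertainty; the expected step is a 10-fold lower number from compound 2 to compound 4 (1.00 log units; beyond the scatter). The estimate for compound 4 is 10000 nM, with a range from 500 nM to 100000 nM.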

Compound 4, concentration for 50% growth inhibition: 77600 nM
Estimate against measurement, compound 4: 7.8-fold (0.89 log units) below; measured number inside the range.
By their numbers in this assay, from the lowest: compound 1; then compound 3; then compounds 4 and 2 (each within the scatter of the next).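

In this assay the 1-methyl-1H-pyrazol-5-yl and furan-3-yl rings on the carbonyl carbon cannot be told apart (a 1.3-fold lower number from compound 2 to compound 4 (0.11 log units; within the scatter)), even though the rings differ in their hetero atoms and in size. A high number at this position is therefore not confined to furan-3-yl, and among these four compounds, both rings without sulfur sit far from thiophen-3-yl (a 46-fold higher number from compound 3 to compound 4 (1.66 log units; beyond the scatter)) and from thiophen-2-yl (a 1800-fold higher number from compound 1 to compound 4 (3.26 log units; beyond the scatter)), which gives compound 1 the most potent result of the set. Nothing available here explains why these rings behave so differently.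

Going by these compounds, it remains open whether a six-membered ring such as phenyl or pyridine, or a thiazole ring with both sulfur and nitrogen, could match thiophen-2-yl. Also open, on these data alone, is how a shorter chain between the amide and the shared core would change the picture.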